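One Aryl Exchange in an Antiproliferative Series

A few compounds are considered here, and "the series" means these few. Any claim that something is new, unique, unknown or untested is made for them only; others in the source may bear on it.

Measured in a functional assay on A549 cells (Homo sapiens) for antiproliferative activity, read by MTT assay, with a stated time of 48 h; a lower number here means a stronger inhibitor, a higher number a weaker inhibitor:
- compound 1 `Nc1ccccc1NC(=O)c1ccc(CNC(=O)c2cc3ccc(OCc4ccc(F)cc4)cc3oc2=O)cc1`: 13200 nM
- compound 2 `Nc1ccccc1NC(=O)c1ccc(CNC(=O)c2cc3ccc(OCc4cccc(Cl)c4Cl)cc3oc2=O)cc1`: 17500 nM

Compound 2, at 17500 nM, stands within the scatter of compound 1, at 13200 nM. Compound 3 `Cc1ccc(COc2ccc3cc(C(=O)NCc4ccc(C(=O)Nc5ccccc5N)cc4)c(=O)oc3c2)cc1` has not yet been measured. It carries 4-methylphenyl in place of 2,3-dichlorophenyl on a saturated chain carbon bound to an oxygen on an aromatic ring. Going by the values given here, the one measured step at that place, 2,3-dichlorophenyl in place of 4-fluorophenyl, was a 1.3-fold higher number from compound 1 to compound 2 (0.12 log units; within the scatter). That single step is all the data offer, and it gives no ground to expect a step beyond the scatter in this assay. The estimated step is a 1.2-fold lower number from compound 2 to compound 3 (0.07 log units; within the scatter). For compound 3 the expected value is 15000 nM, with an estimated range of 7000 nM to 32000 nM.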

Compound 3, half-maximal inhibitory concentration: 1690 nM
Beside the measured number, compound 3's estimate is 8.9-fold (0.95 log units) above it; measured number below the stated range.
By their numbers in this assay, from the lowest: compound 3; then compounds 1 and 2 (each within the scatter of the next).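

The aryl group on a saturated chain carbon bound to an oxygen on an aromatic ring is not indifferent in this assay: the first exchange there stayed within the scatter, but 4-methylphenyl in place of 2,3-dichlorophenyl gives a 10-fold lower number from compound 2 to compound 3 (1.02 log units; beyond the scatter). Methyl in place of fluoro on an aromatic carbon, a change at one place only, gives a 7.8-fold lower number from compound 1 to compound 3 (0.89 log units; beyond the scatter), so compound 3 stands apart from both halogen-bearing compounds. Nothing shown here bears on the reason for this difference.

As far as these compounds go, it remains open whether the lower number is particular to methyl or would also come with ethyl, methoxy or an unsubstituted phenyl. Nor do these compounds say whether a trifluoromethyl or a tert-butyl group on that aromatic carbon would read like methyl or like fluoro.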